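A Sugar Epimer and Its Lipophilicity

The source may hold more compounds than are shown below. What is called first, only, known or untested is meant among the compounds shown, and "the series" means these compounds.

Compound 1 `CN(CCO[C@@H]1O[C@H](CO)[C@@H](O)[C@H](O)[C@H]1O)C(=O)Cn1ccnc1[N+](=O)[O-]` — in a physicochemical assay for lipophilicity, using the shake flask method (a higher number here means a more lipophilic compound, a lower number a more polar compound), compound 1 gives < 0.01, which is a limit of the assay rather than a number.
Compound 2 `CC(=O)OC[C@H]1O[C@H](OCCN(C)C(=O)Cn2ccnc2[N+](=O)[O-])[C@@H](OC(C)=O)[C@@H](OC(C)=O)[C@@H]1OC(C)=O` — in this assay compound 2 gives 0.0697.

Going by the values given here, compound 2 therefore holds the only actual number here; the other value is the limit of < 0.01 in this assay, at which 1 of the 2 values shown sits. Compound 3 `CC(=O)OC[C@H]1O[C@@H](OCCN(C)C(=O)Cn2ccnc2[N+](=O)[O-])[C@H](OC(C)=O)[C@@H](OC(C)=O)[C@H]1OC(C)=O` differs from compound 2 in this way: the two compounds have the same atoms and bonds and differ only in configuration as drawn: 3 of 5 stereo elements differ; a stereocentre at a saturated ring carbon is drawn S in compound 2 and R in compound 3; a stereocentre at a saturated ring carbon is drawn S in compound 2 and R in compound 3; a stereocentre at a saturated ring carbon is drawn R in compound 2 and S in compound 3. Among the compounds with values here, no step between measured compounds is available to guide the comparison. Since the same atoms and bonds are present and only the drawn configuration changes, the shift in this assay is expected to stay within the scatter, with no direction favoured. The expected step is a number 0.00 log units higher from compound 2 to compound 3 (within the scatter). Compound 3 is estimated at 0.07, with a range from -0.25 to 0.4.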

Compound 3, partition coefficient: 0.0355
For compound 3 the middle estimate is 0.03 log units above the measured one; the range from low to high includes it.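

In this assay, changing three stereocentres at saturated ring carbons at once gives a step of a number 0.03 log units lower from compound 2 to compound 3 (within the scatter). Going by these compounds alone, this is the only step available here, and it isolates configuration from every other structural change: the fact that compounds 2 and 3 differ only in the configuration as drawn So, for this pair, the drawn configuration of these three ring carbons leaves no shift that can be told apart from the scatter.

On these data alone, how each of the three stereocentres behaves alone stays open. So does whether configuration would matter as little with an amine or a carboxylic acid in place of the acetyl groups.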